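Swapping the Sulfur Group on a Fluoro-Substituted Imidazoline

The source may report more compounds than this note shows. Statements on the series, on what has been measured and on what is new or still open speak of the compounds shown alone.

Measured so far:
- compound 1 `CSc1ccc(C)cc1NCC1=NCCN1` gives 81%
- compound 2 `CS(=O)(=O)c1ccc(F)cc1NCC1=NCCN1` gives 91%

These two compounds were tested in a functional assay on CHO cells for agonist activity at Alpha-2C adrenergic receptor (Homo sapiens); on this read-out higher numbers stand for larger maximal responses and lower numbers for smaller maximal responses. Compound 2 has the higher of the two numbers, but compound 1 sits only within the usual scatter of it, so the two cannot be told apart by order. Within the data shown here, they also differ in two places at once, so no single step between them can be read off.

Compound 3 `CSc1ccc(F)cc1NCC1=NCCN1` is the next compound and has not yet been measured. Its change from compound 2 is methylsulfanyl in place of methylsulfonyl on an aromatic carbon; the fluoro group is kept, and only the sulfur-bearing group changes.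

Among the measured compounds shown here, no measured step of this kind exists, so the size of the effect in this assay is open. Compound 1 already carries methylsulfanyl and gives 81%, which suggests that this group is compatible with a large response. A step of a number 7 percentage points lower from compound 2 to compound 3 (within the scatter) is therefore expected, that is none beyond the scatter. Compound 3 is estimated to give 84%, with a range from 70% to 98%.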

Compound 3, largest response reached (reported as maximum), in percent of the reference or control that the assay uses: 97%
Estimate against measurement, compound 3: 13 percentage points below, and the stated range covers the measured number.
By their numbers in this assay, from the lowest: compounds 1, 2 and 3 (each within the scatter of the next, the first and the last beyond it).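

In this assay, methylsulfanyl in place of methylsulfonyl on this aromatic carbon, para to a fluoro group, gives a number 6 percentage points higher from compound 2 to compound 3 (within the scatter), so with the fluoro group kept, these two sulfur-bearing groups cannot be told apart on maximal response. Keeping methylsulfanyl and placing fluoro in place of methyl on an aromatic carbon gives a number 16 percentage points higher from compound 1 to compound 3 (beyond the scatter), and this is the only single-place step shown here that clears the usual scatter, which points to the fluoro-for-methyl swap rather than the sulfur-bearing group as the change that registers in this small set. No accompanying measurement bears on why either step has the size it does.

Going by these compounds, whether this aromatic carbon would keep so large a response with a group lacking sulfur, such as an amine, a carboxylic acid or a longer chain, remains open. Also open, on these data alone, is whether the fluoro-for-methyl step would have the same size with methylsulfonyl on the ring, and these maximal responses alone say nothing about how low a concentration each compound needs to reach them.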